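Branched and benzylic groups on the indole-type nitrogen

The compounds below may be only part of what the source reports. "The series", "measured", "known", "first", "only" and "open" are said of these compounds alone.

- Compound 1 `CCCC(C)n1ccc2cc(/C(C)=C/C(=O)Nc3ccccc3OCCCC(=O)O)ccc21`: 7.8 nM
- Compound 2 `CCCC(CC)n1ccc2cc(/C(C)=C/C(=O)Nc3ccccc3OCCCC(=O)O)ccc21`: 9.3 nM
- Compound 3 `C/C(=C\C(=O)Nc1ccccc1OCCCC(=O)O)c1ccc2c(ccn2Cc2ccc(C)cc2)c1`: 88 nM

In an assay on Prostate gland for inhibition of steroid 5-alpha-reductase (Rattus norvegicus) (on this read-out lower numbers stand for stronger inhibition and higher numbers for weaker inhibition), compound 1 gives 7.8 nM, the lowest of the three numbers; compound 2 lies within the scatter of it, a 1.2-fold higher number from compound 1 to compound 2 (0.08 log units; within the scatter), and compound 3 is the furthest away, an 11-fold higher number from compound 1 to compound 3 (1.05 log units; beyond the scatter).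

Compound 4 `CCCCCC(c1ccccc1)n1ccc2cc(/C(C)=C/C(=O)Nc3ccccc3OCCCC(=O)O)ccc21` has not yet been measured. It differs from compound 1 in one place: 1-phenylhexyl in place of 1-methylbutyl on an aromatic nitrogen. Among the measured compounds shown here, two measured steps bear on this change. The branched-chain step a 1.2-fold higher number from compound 1 to compound 2 (0.08 log units; within the scatter) shows that adding a methyl on the saturated chain carbon does nothing beyond the scatter. The steps to the 4-methylbenzyl compound, an 11-fold higher number from compound 1 to compound 3 (1.05 log units; beyond the scatter) and a 9.5-fold higher number from compound 2 to compound 3 (0.98 log units; beyond the scatter), are both beyond the scatter and in the weakening direction. The group entering in compound 4 keeps the branching of compound 1 but also carries a six-membered aromatic ring, so a modest loss is expected, a 2.6-fold higher number from compound 1 to compound 4 (0.41 log units; beyond the scatter), smaller than the loss to compound 3. Compound 4 is therefore estimated at 20 nM, with a range from 6 nM to 70 nM.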

Compound 4, half-maximal inhibitory concentration: 25 nM
Estimate against measurement, compound 4: 1.3-fold (0.10 log units) below; the range from low to high includes it.
By their numbers in this assay, from the lowest: compounds 1 and 2 (each within the scatter of the next); then compound 4; then compound 3.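

In this assay, 1-phenylhexyl on the aromatic nitrogen gives a 3.2-fold higher number from compound 1 to compound 4 (0.51 log units; beyond the scatter), and the same loss appears against 1-ethylbutyl, with a 2.7-fold higher number from compound 2 to compound 4 (0.43 log units; beyond the scatter), so a six-membered aromatic ring at this position costs less here than the earlier 4-methylbenzyl result alone suggested. Both ring-bearing groups remain weaker than the two branched alkyl groups, yet they differ from each other, with a 3.5-fold lower number from compound 3 to compound 4 (0.55 log units; beyond the scatter), so the presence of the ring does not alone set the number. No supporting measurement bears on the reason for these differences.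

The change to 1-phenylhexyl alters the ring and the chain together, so their separate contributions remain unresolved. As far as these compounds go, whether 1-phenylethyl or a straight hexyl chain on the same nitrogen would stand nearer compound 1 or compound 4 stays open.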